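Methyl at the Ring Carbon Beside Nitrogen: Compound 4

The source may report more compounds than this note shows. Statements on the series, on what has been measured and on what is new or still open speak of the compounds shown alone.

Measured so far:
- compound 1, `Cc1ccccc1Cc1ccc(N2CCC[C@H]2CC(=O)O)cc1`: > 33000 nM
- compound 2, `Cc1ccccc1Cc1ccc(N2C[C@@H](C(F)(F)F)C[C@H]2CC(=O)O)cc1`: 710 nM
- compound 3, `Cc1ccccc1Cc1ccc(N2C[C@@H](c3ccccc3)C[C@H]2CC(=O)O)cc1`: > 33000 nM

In a functional assay on cells for agonist activity at Free fatty acid receptor 1 (Mus musculus), read by FLIPR and calcium flux, with a stated time of 100 s (on this read-out lower numbers stand for an effect already at smaller amounts and higher numbers for an effect only at larger amounts of compound), compound 1 gives only a limit, > 33000 nM. Compound 2 gives 710 nM. Compound 3 gives a limit too, > 33000 nM; two of the three values sit at the limit of > 33000 nM in this assay, at which 2 of the 3 values shown sit.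

Compound 4, `Cc1ccccc1Cc1ccc(N2[C@H](CC(=O)O)CC[C@@H]2C)cc1`, differs from compound 1 by methyl in place of hydrogen on a saturated ring carbon. Going by the values given here, no measured step alters this ring position. The steps at the other saturated ring carbon were an at least 46-fold lower number from compound 1 to compound 2 (1.66 log units; beyond the scatter) and an at least 46-fold higher number from compound 2 to compound 3 (1.66 log units; beyond the scatter), while a step that the two limits leave unreadable from compound 1 to compound 3. A methyl is smaller than either group there, so compound 4 is expected to stay near the limit of compound 1, perhaps a modestly lower number: an estimate of 20000 nM, between 4000 nM and 100000 nM, meaning an at least 1.6-fold lower number from compound 1 to compound 4 (0.21 log units; that floor lies within the scatter) is expected.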

Compound 4, half-maximal effective concentration: > 33000 nM
Compound 4: no number, only a limit; the forecaster's own chance of this, stated with the estimate: 55%; middle value at least 1.6-fold (0.21 log units) away from the limit.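

In this assay compound 4 gives only a limit, > 33000 nM; compound 1 also gives only a limit, so the step between them cannot be read. The compounds shown leave open whether methyl in place of hydrogen on this ring carbon changes the read-out at all.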